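Replacing the carboxy group of compound 2 with a hydroxypropyl chain

The source may report more compounds than this note shows. Statements on the series, on what has been measured and on what is new or still open speak of the compounds shown alone.

Going by the values given here, compound 2 `O=C(O)COc1cccc(CC(C(=O)O)c2nc(-c3ccccc3)c(-c3ccccc3)o2)c1` stands second highest of the three numbers so far in a functional assay for inhibition, with Homo sapiens as the target (a lower number here means a stronger inhibitor, a higher number a weaker inhibitor), where compound 2 gives 14000 nM. Compound 1 `CCOC(=O)/C(=C\c1cccc(OCC(=O)O)c1OC)c1nc(-c2ccccc2)c(-c2ccccc2)o1` gives 130 nM and compound 3 `O=C(O)COc1cccc(CC(c2nc(-c3ccccc3)c(-c3ccccc3)o2)c2cccs2)c1` gives 33200 nM. Compound 4 `O=C(O)COc1cccc(CC(CCCO)c2nc(-c3ccccc3)c(-c3ccccc3)o2)c1` differs from compound 2 as follows: 3-hydroxypropyl in place of carboxy on a saturated chain carbon bound to an aromatic carbon and a saturated chain carbon. Among the compounds with values here, the one measured step at the same place, a 2.4-fold higher number from compound 2 to compound 3 (0.38 log units; beyond the scatter), also removed the carboxy group and gave a modest weakening. That precedent suggests a step from compound 2 to compound 4 of similar size, expected to be a 1.6-fold higher number from compound 2 to compound 4 (0.20 log units; within the scatter), toward a higher number or none beyond the scatter. Compound 4 is therefore expected to give about 22000 nM, with a likely range from 8000 nM to 60000 nM.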

Compound 4, half-maximal inhibitory concentration: 1700 nM
Beside the measured number, compound 4's estimate is 13-fold (1.11 log units) above it, and the stated range ends above it.
By their numbers in this assay, from the lowest: compound 1; then compound 4; then compound 2; then compound 3.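

In this assay, losing the carboxy group does not in itself weaken inhibition at this position: 3-hydroxypropyl brings an 8.2-fold lower number from compound 2 to compound 4 (0.92 log units; beyond the scatter) and, in place of thiophen-2-yl, a 20-fold lower number from compound 3 to compound 4 (1.29 log units; beyond the scatter) as well. The earlier step had shown only a weakening, so the direction of change at this saturated chain carbon depends on the group that enters. Nothing available here accounts for the gain.

The compounds shown leave open whether the terminal hydroxyl or the chain itself carries the gain. A plain propyl chain, a hydroxyethyl or hydroxybutyl chain, or a terminal amine would separate these.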